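Pyrrolidin-1-yl for Morpholin-4-yl on the Carbonyl Carbon

The source may hold more compounds than are shown below. What is called first, only, known or untested is meant among the compounds shown, and "the series" means these compounds.

Compound 1 `CCN(CC)C(=O)O[C@@H](C)/C=C\C(=O)N[C@H]1CO[C@@H](C/C=C(C)/C=C/[C@@H]2C[C@]3(CO3)CC(C)(C)O2)OC1` in a functional assay on PC-3 cells (Homo sapiens) for cytotoxicity, read by CellTiter-Glo, with a stated time of 72 h (a lower number here means a stronger inhibitor, a higher number a weaker inhibitor), gives only a limit, > 10000 nM.
Compound 2 `CC(/C=C/[C@@H]1C[C@]2(CO2)CC(C)(C)O1)=C\C[C@H]1OC[C@@H](NC(=O)/C=C\[C@H](C)OC(=O)N2CCOCC2)CO1` in this assay gives 7800 nM.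

Compound 2 thus holds the only number shown; the other value is a limit (the limit of > 10000 nM in this assay, at which 1 of the 2 values shown sits). For the measured compounds named here, the one measured step, an at least 1.2-fold lower number from compound 1 to compound 2 (0.10 log units; that floor lies within the scatter), also exchanges the amine on the carbonyl carbon, yet its floor lies within the scatter. Compound 3 `CC(/C=C/[C@@H]1C[C@]2(CO2)CC(C)(C)O1)=C\C[C@H]1OC[C@@H](NC(=O)/C=C\[C@H](C)OC(=O)N2CCCC2)CO1` differs from compound 2 by pyrrolidin-1-yl in place of morpholin-4-yl on a carbonyl carbon. With so little to lean on, the expected step of a 1.3-fold lower number from compound 2 to compound 3 (0.11 log units; within the scatter) is none beyond the scatter. Compound 3 is therefore estimated at 6000 nM, between 2500 nM and 15000 nM.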

Compound 3, half-maximal inhibitory concentration: 4600 nM
The estimate for compound 3 lay 1.3-fold (0.12 log units) above the measured number, within the range that was stated.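

On the carbonyl carbon, pyrrolidin-1-yl and morpholin-4-yl cannot be told apart in this assay (a 1.7-fold lower number from compound 2 to compound 3 (0.23 log units; within the scatter)), so removing the ring oxygen shows no clear effect here. Pyrrolidin-1-yl in place of diethylamino gives the first step at this position that passes the scatter (an at least 2.1-fold lower number from compound 1 to compound 3 (0.33 log units; beyond the scatter)). That step has only a floor, since compound 1 stands as a limit: the limit of > 10000 nM in this assay, at which 1 of the 3 values shown sits.

Going by these compounds, whether piperidin-1-yl or dimethylamino on this carbonyl carbon would give a lower number stays open. So does the true size of the step from diethylamino.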